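Swapping the Aryl Group at a Saturated Ring Carbon

The source may report more compounds than this note shows. Statements on the series, on what has been measured and on what is new or still open speak of the compounds shown alone.

Three compounds share one core and differ only in the group on a saturated ring carbon. Compound 1 `COc1cc(N2C(N)=C(C#N)C(c3cccc([N+](=O)[O-])c3)C3=C2CC(C)(C)CC3=O)cc(OC)c1OC` carries a 3-nitrophenyl group there, and in a functional assay on Ehrlich cells (Mus musculus) for cytotoxicity, tested at 10 ug/mL (a higher number here means a stronger effect of the compound at the concentration tested, a lower number a weaker effect), compound 1 gives 5%. Compound 2 `COc1cc(N2C(N)=C(C#N)C(c3cccs3)C3=C2CC(C)(C)CC3=O)cc(OC)c1OC` carries a thiophen-2-yl group, and in this assay compound 2 gives 5%, so that no change at the digits printed from compound 1 to compound 2 (within the scatter). Compound 3 `COc1cc(N2C(N)=C(C#N)C(c3ccc(C)cc3)C3=C2CC(C)(C)CC3=O)cc(OC)c1OC` carries a 4-methylphenyl group, and in this assay compound 3 gives 30%, the highest of the three numbers: both a number 25 percentage points higher from compound 1 to compound 3 (beyond the scatter) and a number 25 percentage points higher from compound 2 to compound 3 (beyond the scatter) lie beyond the scatter.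

Compound 4 `COc1cc(N2C(N)=C(C#N)C(/C=C/c3ccccc3)C3=C2CC(C)(C)CC3=O)cc(OC)c1OC` is the next compound. Relative to compound 3, the change is 2-phenylethenyl in place of 4-methylphenyl on a saturated ring carbon. Among the measured compounds shown here, no measured step brings in a 2-phenylethenyl group, so nothing bears directly on this change. What the measured steps do show is that the group at this position matters by a modest amount, since a number 25 percentage points higher from compound 1 to compound 3 (beyond the scatter) and a number 25 percentage points higher from compound 2 to compound 3 (beyond the scatter) both cross the scatter while only the 4-methylphenyl group of compound 3 reaches the higher number. A move back toward the smaller numbers is therefore the more likely expectation, though a number near that of compound 3 cannot be ruled out. Compound 4 is expected to give 15%, within 3% to 40%, an expected step of a number 15 percentage points lower from compound 3 to compound 4 (beyond the scatter).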

Compound 4, a percentage reported as activity, at one concentration (the size of the read-out at that concentration, not a potency): 10%
Compound 4: middle estimate off by 5 percentage points, on the high side, and the stated range covers the measured number.
By their numbers in this assay, from the lowest: compounds 1, 2 and 4 (each within the scatter of the next); then compound 3.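

In this assay, keeping a six-membered aromatic ring of carbon only at this saturated ring carbon is not enough to hold the higher number: the 2-phenylethenyl group gives a number 20 percentage points lower from compound 3 to compound 4 (beyond the scatter) even though the ring is still there, now joined through a double bond outside aromatic rings. Set against the other two groups, the same compound shows a number 5 percentage points higher from compound 2 to compound 4 (within the scatter) and a number 5 percentage points higher from compound 1 to compound 4 (within the scatter) so that 2-phenylethenyl, thiophen-2-yl and 3-nitrophenyl cannot be told apart here, and among the four groups compound 3 with its 4-methylphenyl group is the only one that stands clear of the rest. Nothing measured on these compounds offers an explanation for why this one group stands apart.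

The compounds shown leave open whether the methyl group on the ring of compound 3 matters at all, which a plain phenyl group or a 4-methoxyphenyl group at the same carbon would help to settle. They also leave open whether the double bond of compound 4 counts, which a 2-phenylethyl group, the same chain with a single bond, would test directly.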